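The source may hold more compounds than are shown below. What is called first, only, known or untested is meant among the compounds shown, and "the series" means these compounds.

Measured so far in an assay on HEK293 cells for inhibition of melanin-concentrating hormone receptor 1 (Homo sapiens), read by radioligand binding; a higher number here means a weaker inhibitor, a lower number a stronger inhibitor: compound 1, `CN(Cc1ccc(Br)cc1OC(F)(F)F)CC1CCC(CNc2nc(N(C)C)c3ccccc3n2)CC1`, gives 5600 nM; compound 2, `CN(C)c1nc(N[C@H]2CC[C@@H](NC(=O)c3ccc(F)c(F)c3F)CC2)nc2ccccc12`, gives 38 nM.

Compound 2 holds the lower of the two numbers in this assay, with compound 1 far higher, well beyond the scatter. Compound 3, `CN(C)c1nc(N[C@H]2CC[C@@H](NC(=O)c3cccc(F)c3)CC2)nc2ccccc12`, awaits measurement in this assay. It differs from compound 2 by 3-fluorophenyl in place of 2,3,4-trifluorophenyl on a carbonyl carbon. Within the data shown here, no measured pair carries this change, so no step size is known. A modest move toward a higher number is expected, about a 2.1-fold higher number from compound 2 to compound 3 (0.32 log units; beyond the scatter), close to the edge of the scatter. For compound 3 the estimate in this assay is 80 nM, expected to fall between 25 nM and 250 nM.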

Compound 3, half-maximal inhibitory concentration: 9.5 nM
The estimate for compound 3 lay 8.4-fold (0.93 log units) above the measured number, outside the stated range (below it).
By their numbers in this assay, from the lowest: compound 3; then compound 2; then compound 1.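

On the aryl group on a carbonyl carbon whose other neighbour is the amide-type nitrogen, 3-fluorophenyl in place of 2,3,4-trifluorophenyl gives a 4.0-fold lower number from compound 2 to compound 3 (0.60 log units; beyond the scatter) in this assay, so compound 3 is the stronger inhibitor. This position therefore responds to the fluorine pattern, and the full trifluorinated pattern is not required for activity in this pair. Nothing available explains the step.

On these data alone, both fluorines leave together, so their separate contributions remain unknown. Unsubstituted phenyl, or a chlorine or methoxy group replacing the remaining fluorine, would test whether that fluorine matters.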